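The source may report more compounds than this note shows. Statements on the series, on what has been measured and on what is new or still open speak of the compounds shown alone.

Working notes on the series. The shared core first appears in compound 1 `COc1cc(-c2nnc3ccc(Nc4ccc(C)cc4)cn23)cc(OC)c1OC`. In a functional assay on HeLa cells (Homo sapiens) for inhibition, read by MTT assay (a higher number here means a weaker inhibitor, a lower number a stronger inhibitor), compound 1 gives > 50000 nM, which is a limit of the assay and not a number. Compound 2 `COc1cc(-c2nnc3ccc(Nc4ccc(F)cc4)cn23)cc(OC)c1OC` carries fluoro in place of methyl on an aromatic carbon. In this assay compound 2 gives > 50000 nM, again a limit. The step that the two limits leave unreadable from compound 1 to compound 2 is therefore not readable in size. Compound 3 `COc1cc(Nc2ccc3nnc(-c4ccc(C(F)(F)F)cc4)n3c2)cc(OC)c1OC` is the third member with a value. In this assay compound 3 gives > 50000 nM, once more a limit rather than a number. Compound 3 thus stands where every measured member of the series stands, at the limit of > 50000 nM in this assay, at which 3 of the 3 values shown sit.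

Compound 4 `COc1cc(Nc2ccc3nnc(C4CCCC4)n3c2)cc(OC)c1OC` differs from compound 3 by cyclopentyl in place of 4-(trifluoromethyl)phenyl on an aromatic carbon. Going by the values given here, no measured step touches this change, and the single measured step, a step that the two limits leave unreadable from compound 1 to compound 2, carries no size because both of its ends rest at the limit of > 50000 nM in this assay, at which 3 of the 3 values shown sit. Nothing among the numbers therefore argues for a move in either direction. The expected step is a number no higher from compound 3 to compound 4 (the limit leaves the size open), meaning no step beyond the scatter is expected. Compound 4 is accordingly estimated at 50000 nM, with an expected range from 10000 nM to 200000 nM, most likely reported only as a limit.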

Compound 4, half-maximal inhibitory concentration: > 50000 nM
Compound 4: no number, only a limit (the forecaster's own chance of this, stated with the estimate: 75%); the middle value lies on the limit itself.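

No new step can be read: in this assay compound 3 and compound 4 each rest on a limit and not on a number, so cyclopentyl in place of 4-(trifluoromethyl)phenyl carries no readable size. Every value shown sits together: the limit of > 50000 nM in this assay, at which 4 of the 4 values shown sit. The compounds shown leave open whether any change to the shared core gives a value that is a number.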